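This account rests on a few compounds, and the source may have more. Where it says the series, first, only, none or still open, it means among the compounds named here.

Of the compounds shown here, two of the shared core have numbers so far. In an in vitro assay on SH-EP1 cells for displacement of a labelled ligand from Neuronal acetylcholine receptor; alpha4/beta2 (Homo sapiens) (a lower number here means a stronger inhibitor, a higher number a weaker inhibitor), compound 1 `Clc1ccncc1C1=CC2CNCC(C1)C2` gives 3 nM; compound 2 `C1=C(c2cncc(OCc3ccccc3)c2)CC2CNCC1C2` gives 0.7 nM, the lower of the two numbers, and the gap between them lies beyond the usual scatter. Compound 3 `COc1cncc(C2=CC3CNCC(C2)C3)c1` keeps the core and the aromatic ether of compound 2 but carries hydrogen in place of phenyl on a saturated chain carbon bound to an oxygen on an aromatic ring. Among the compounds with values here, no measured pair shows this change, so the step is estimated rather than read: a loss of binding is expected for compound 3, of size a 4.3-fold higher number from compound 2 to compound 3 (0.63 log units; beyond the scatter) in this assay. Compound 3 is therefore expected to give 3 nM, within a range of 0.8 nM to 12 nM.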

Compound 3, inhibition constant: 0.3 nM
The estimate for compound 3 lay 10-fold (1.00 log units) above the measured number, and the stated range ends above it.
By their numbers in this assay, from the lowest: compound 3; then compound 2; then compound 1.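

Going from benzyl to methyl in this assay gives a 2.3-fold lower number from compound 2 to compound 3 (0.37 log units; beyond the scatter) and so shows that the phenyl is not needed for strong binding at this place, on a saturated chain carbon bound to an oxygen on an aromatic ring. Here the smaller ether gives the lower number, with compound 3 at 0.3 nM as the lowest value so far. Nothing at hand explains this direction. Open, on these data alone, is whether an ethyl or a longer chain falls between methyl and benzyl, and whether an amine can replace the ether oxygen.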